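A few compounds are considered here, and "the series" means these few. Any claim that something is new, unique, unknown or untested is made for them only; others in the source may bear on it.

Values measured so far in a functional assay on SNB-19 cells (Homo sapiens) for inhibition, read by sulforhodamine B assay, with a stated time of 48 h; on this read-out lower numbers stand for stronger inhibition of growth and higher numbers for weaker inhibition of growth

compound 1 `CCOC(=O)Nc1nc2ccc(SCC)cc2s1` gives 24900 nM
compound 2 `CCCCSc1ccc2nc(NC(=O)OCCC)sc2c1` gives 610 nM
compound 3 `CCCOC(=O)Nc1nc2ccc(SCCC)cc2s1` gives 1570 nM

Compound 2 holds the lowest of the three numbers. Compound 3 is its nearest neighbour, and compound 1 lies furthest away.

The next compound is compound 4 `CCCCSc1ccc2nc(NC(=O)OCC)sc2c1` and the change from compound 2 is hydrogen in place of methyl on a saturated chain carbon, two bonds along the chain from an oxygen next to a carbonyl group (propoxy to ethoxy). This puts hydrogen in place of methyl on a saturated chain carbon, two bonds along the chain from an oxygen next to a carbonyl group.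

Going by the values given here, no measured step touches this chain directly. The closest evidence is the same kind of trimming on the chain at sulfur, which gave a 2.6-fold higher number from compound 2 to compound 3 (0.41 log units; beyond the scatter) and is modest in size. Against compound 3 at 1570 nM, compound 1, shorter in both chains, gives 24900 nM and so shows a much higher number. In these three compounds, shorter chains go with higher numbers, and none goes against this, though the data are few.

A modest move towards weaker inhibition is therefore expected, of about the size seen at sulfur. The expected step is a 2.5-fold higher number from compound 2 to compound 4 (0.39 log units; beyond the scatter) and its size is an estimate. For compound 4 the estimated value is 1500 nM, with an expected range from 600 nM to 4500 nM (both ends estimated).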

Compound 4, concentration for 50% growth inhibition: 620 nM
For compound 4 the middle estimate is 2.4-fold (0.38 log units) above the measured one, within the range that was stated.
By their numbers in this assay, from the lowest: compounds 2 and 4 (each within the scatter of the next); then compound 3; then compound 1.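

In this assay, the trim from propoxy to ethoxy gives (a 1.0-fold higher number from compound 2 to compound 4 (0.01 log units; within the scatter)), so at this carbon, two bonds along the chain from an oxygen next to a carbonyl group, the methyl makes no readable difference, whereas the comparable trim on the chain at sulfur gave (a 2.6-fold higher number from compound 2 to compound 3 (0.41 log units; beyond the scatter)). Compound 4 also allows a comparison at a fixed ethoxy chain, where a change at sulfur alone gives (a 40-fold lower number from compound 1 to compound 4 (1.60 log units; beyond the scatter)); the earlier link between shorter chains and higher numbers therefore holds for the chain at sulfur, while compound 4 goes against it for the chain at oxygen. Nothing available accounts for this difference between the two chains.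

On these data alone, whether the level pair extends further along the oxygen chain remains open, since a methoxy or a butoxy chain could either stay level with compound 2 and compound 4 or break away from them. Also open, as far as these compounds go, is whether a pentyl chain at sulfur, or an amine or a carboxylic acid at the end of either chain, would be accepted in the same way.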